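Amide-nitrogen substituent exchange on compound 3

This account rests on a few compounds, and the source may have more. Where it says the series, first, only, none or still open, it means among the compounds named here.

Compound 3 `Cc1cccc(Oc2ccnc(N3CCC[C@H]3C(=O)NCCCn3ccnc3)n2)c1` gives 0% in an assay on isolated protein for inhibition of vascular endothelial growth factor receptor 1 (Homo sapiens), read by HTRF, tested at 10 uM (a lower number here means less inhibition, a higher number more inhibition at the concentration tested (going by the name of the read-out)), level with compound 1 `Cc1cccc(Oc2ccnc(N3CCC[C@H]3C(=O)NCc3cccnc3)n2)c1`, which gives 0%; together these are the lowest of the three numbers. Compound 2 `O=C(C1CCN(c2nccc(Nc3ccccc3)n2)CC1)N1CC[C@@H](O)C1`, the furthest of the set, gives 6%, still within the scatter of compound 3. Among the compounds with values here, the single measured step, no change at the digits printed from compound 1 to compound 3 (within the scatter), replaced one group on the same amide-type nitrogen and moved nothing beyond the scatter. Compound 4 `COC(=O)C(CO)NC(=O)[C@@H]1CCCN1c1nccc(Oc2cccc(C)c2)n1` differs from compound 3 by 2-hydroxy-1-(methoxycarbonyl)ethyl in place of 3-(1H-imidazol-1-yl)propyl on an amide-type nitrogen. Within the data shown here, only that one flat step bears on this change, and every number in the set sits near the bottom of the scale, so no movement beyond the scatter is expected in this assay . Compound 4 is therefore estimated at 2%, between 0% and 12%. The expected step is a number 2 percentage points higher from compound 3 to compound 4 (within the scatter).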

Compound 4, a percentage reported as inhibition, at one concentration (the size of the read-out at that concentration, not a potency): 0%
The estimate for compound 4 lay 2 percentage points above the measured number, within the range that was stated.
By their numbers in this assay, from the lowest: compounds 1, 3, 4 and 2 (each within the scatter of the next).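

At the amide-type nitrogen, this assay gives no change at the digits printed from compound 3 to compound 4 (within the scatter) and no change at the digits printed from compound 1 to compound 4 (within the scatter). The open-chain 2-hydroxy-1-(methoxycarbonyl)ethyl, with no ring, therefore does not separate from either ring-bearing group, 3-(1H-imidazol-1-yl)propyl or (pyridin-3-yl)methyl, so across these three substituents the presence of a five-membered or pyridine ring makes no readable difference. No measurement is available to explain these flat steps.

Still open, on these data alone, is whether a primary amine or a carboxylic acid on this chain would move the number beyond the scatter. With compounds 1, 3 and 4 all at the bottom of the scale, a substituent effect at this nitrogen remains undetected.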